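Replacing a piperazine ring with an open diethylaminopropyl chain

The source may hold more compounds than are shown below. What is called first, only, known or untested is meant among the compounds shown, and "the series" means these compounds.

Measured so far, each in an ADME assay on Huh-7 cells (Homo sapiens) for cytotoxicity; a lower number here means that less compound is tolerated, a higher number that more compound is tolerated:
Compound 1 `Cc1ccccc1-c1nn(-c2ccc(F)cc2F)cc1CNCCCN1CCN(C)CC1` gives > 20000 nM, a limit of the assay rather than a number.
Compound 2 `CCCN1CCC(CNCc2cn(-c3ccc(F)cc3F)nc2-c2ccccc2C)CC1` gives > 20000 nM, again a limit.
Compound 3 `Cc1ccccc1-c1nn(-c2ccc(F)cc2F)cc1CN1CCN(C(C)C)CC1` gives > 20000 nM, also a limit.

Compound 3 thus stands at the limit of this assay, as do the two other measured compounds; no number separates them. Among the measured compounds shown here, the single measured step, a step that the two limits leave unreadable from compound 1 to compound 2, swaps one amine-bearing side chain for another, and the two limits leave its size unreadable.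

The step now followed leads from compound 3 to compound 4 `CCN(CC)CCCNCc1cn(-c2ccc(F)cc2F)nc1-c1ccccc1C`. It differs from compound 3 as follows: (3-(diethylamino)propyl)amino in place of 4-isopropylpiperazin-1-yl on a saturated chain carbon bound to an aromatic carbon. This again trades one basic side chain for another of the same size, akin to the change from compound 1 to compound 2.

For the measured compounds named here, the one evidence on hand is the limit of > 20000 nM in this assay, at which 3 of the 3 values shown sit: every measured compound, whatever its side chain, sits at the limit. Going by the values given here, no measured step gives a direction or a size, so no shift beyond the scatter is expected from compound 3 to compound 4, and the step that the limit leaves unreadable from compound 3 to compound 4 is estimated to be small. Compound 4 is therefore expected to show 30000 nM, within a range of 15000 nM to 80000 nM, most likely reported again as a limit.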

Compound 4, half-maximal cytotoxic concentration: > 20000 nM
Compound 4: no number, only a limit (the forecaster's own chance of this, stated with the estimate: 85%); the middle value does not contradict the limit.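

In this assay compound 4 gives > 20000 nM, again a limit of the assay, so none of the steps linking it to compound 1, compound 2 and compound 3 can be read. Whether any of these side chains shifts how much compound is tolerated, and by how much, stays open, as the compounds shown offer only this: the limit of > 20000 nM in this assay, at which 4 of the 4 values shown sit.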